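Swapping pyrazin-2-yl in compound 2: a half-life estimate

This account rests on a few compounds, and the source may have more. Where it says the series, first, only, none or still open, it means among the compounds named here.

Compound 1 (`COc1ccc(-c2nn3c(-c4cccs4)nnc3s2)cc1OC`): 0.0667 h
Compound 2 (`c1csc(-c2nnc3sc(-c4cnccn4)nn23)c1`): 0.1 h

In an ADME assay on microsomes from liver (Homo sapiens) for metabolic stability, read by HPLC, using NADPH, with a stated time of 10 min (a higher number here means that the compound lasts longer, a lower number that the compound disappears faster), compound 1 gives (0.0667 h) and compound 2 gives (0.1 h). With only these two numbers available, compound 2 stands within the usual scatter of compound 1, and the measurements do not separate them.

Compound 3 (`Cc1cc(-c2nn3c(-c4cccs4)nnc3s2)n[nH]1`) has yet to be measured in this assay and follows from compound 2 by a single structural change. It carries 5-methyl-1H-pyrazol-3-yl in place of pyrazin-2-yl on an aromatic carbon.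

Among the measured compounds shown here, no measured pair of compounds shows the size of a single step, so the data give no direct guide to this change. The expectation therefore stays with compound 2 at (0.1 h), with no shift in either direction beyond the scatter. The expected step is no change at the digits printed from compound 2 to compound 3 (within the scatter) and it is not expected to exceed the scatter. The half-life estimated for compound 3 is 0.1 h, with an expected range from 0.05 h to 0.25 h.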

Compound 3, half-life in the liver assay: 0.233 h
Estimate against measurement, compound 3: 2.3-fold (0.37 log units) below, and the stated range covers the measured number.
By their numbers in the liver assay, from the lowest: compounds 1 and 2 (each within the scatter of the next); then compound 3.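

Among the compounds shown here, with this pair, a single change at this position can finally be read: on an aromatic carbon of the five-membered aromatic ring with 2 nitrogen and 1 sulfur, placing 5-methyl-1H-pyrazol-3-yl in place of pyrazin-2-yl gives, in the liver assay, a 2.3-fold higher number from compound 2 to compound 3 (0.37 log units; beyond the scatter) and so moves the half-life by a modest step that the earlier compounds could not show, with compound 2 at 0.1 h and compound 3 at 0.233 h. In a physicochemical assay for solubility, measured as kinetic solubility (a lower number here means a less soluble compound, a higher number a more soluble compound), the same change gives a 1.9-fold higher number from compound 2 to compound 3 (0.29 log units; within the scatter) in solubility, with compound 2 at 30000 nM and compound 3 at 58000 nM, so this pair shows no separable cost or gain there alongside the half-life step. The change keeps the heavy-atom count but replaces a six-membered aromatic ring with a five-membered one and brings in a hydrogen-bond donor, and nothing available ties the step to any one of these differences.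

The compounds shown cannot separate the methyl group from the pyrazole ring that carries it, since both enter together in this one step. They also leave open how a plain phenyl ring, a morpholine or a primary amine on the same aromatic carbon would read in these two assays, and whether the step would hold on another core.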